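The source may hold more compounds than are shown below. What is called first, only, known or untested is meant among the compounds shown, and "the series" means these compounds.

Among the compounds with values here, in a functional assay on MDA-MB-231 cells (Homo sapiens) for cytotoxicity, read by MTT assay, with a stated time of 48 h (a higher number here means a weaker inhibitor, a lower number a stronger inhibitor), compound 1 `Oc1ccc(-c2nc(-c3c[nH]c4ccccc34)co2)cc1` gives 103000 nM, the lowest of the two numbers known, while compound 2 `COc1ccc(-c2nc(-c3c[nH]c4ccccc34)co2)cc1` gives 108000 nM; the one known step, a 1.0-fold higher number from compound 1 to compound 2 (0.02 log units; within the scatter), changes nothing beyond the scatter. Compound 3 `C=Cc1nc(-c2c[nH]c3ccccc23)co1` differs from compound 1 by vinyl in place of 4-hydroxyphenyl on an aromatic carbon. Within the data shown here, no measured step touches this position, so there is no direct precedent. Given that compound 1 already sits at 103000 nM, compound 3 is expected to show a 1.5-fold higher number from compound 1 to compound 3 (0.16 log units; within the scatter), and its estimated value is 150000 nM, in a range from 50000 nM to 500000 nM.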

Compound 3, half-maximal inhibitory concentration: 103000 nM
Compound 3: middle estimate off by 1.5-fold (0.16 log units), on the high side; the measured number falls inside the stated range.
By their numbers in this assay, from the lowest: compounds 1, 3 and 2 (each within the scatter of the next).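

In this assay, replacing the whole 4-hydroxyphenyl with vinyl on this aromatic carbon gives no change at the digits printed from compound 1 to compound 3 (within the scatter). The earlier step changed only the hydrogen on the oxygen, whereas this one removes the six-membered aromatic ring and its hydrogen-bond donor, and the number still stays within the scatter. The aryl ring is therefore not needed to hold this weak level of cytotoxicity.

Going by these compounds, whether an amine, a carboxylic acid or a longer alkyl chain at this position would move the number beyond the scatter remains open. No available evidence bears on why the exchange leaves the number in place.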